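Swapping the aryl amide arm for a phenylcyclopropyl amide

A few compounds are considered here, and "the series" means these few. Any claim that something is new, unique, unknown or untested is made for them only; others in the source may bear on it.

The two measured compounds share a core built from a central ring carrying two amide links, each capped by a further group. Compound 1 `O=C(Nc1cccc(NC(=O)c2ccccc2Cl)c1)c1cccc(Cl)c1` bears a 2-chlorophenyl on one carbonyl carbon. In an in vitro functional assay on HEK293-A cells for antagonist activity at metabotropic glutamate receptor 5 (Rattus norvegicus), read by calcium flux (a lower number here means a stronger inhibitor, a higher number a weaker inhibitor), compound 1 gives 2620 nM. Compound 2 `O=C(Nc1cccc(NC(=O)c2cccc(Cl)c2)c1)c1ccc(F)cc1` carries a 4-fluorophenyl in its place. In this assay compound 2 reaches only the limit > 30000 nM, so no number is known for it. The step of an at least 11-fold higher number from compound 1 to compound 2 (1.05 log units; beyond the scatter) shows that the group on this carbonyl carbon matters, as does (the limit of > 30000 nM in this assay, at which 1 of the 2 values shown sits).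

Compound 3 `O=C(Nc1cccc(NC(=O)C2CC2c2ccccc2)c1)c1cccc(Cl)c1` makes a further change at the same spot: 2-phenylcyclopropyl in place of 4-fluorophenyl on a carbonyl carbon. Among the measured compounds shown here, only the step from compound 1 to compound 2 bears on this, and it was large. Compound 3 is therefore expected to move in this assay by an at least 3.0-fold lower number from compound 2 to compound 3 (0.47 log units; beyond the scatter) toward a stronger inhibitor. The estimate for compound 3 is 10000 nM, within 2000 nM to 30000 nM.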

Compound 3, half-maximal inhibitory concentration: > 30000 nM
Compound 3 was reported as a limit; the forecaster's own chance of this, stated with the estimate: 40%; middle value at least 3.0-fold (0.47 log units) away from the limit.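

Replacing the 2-chlorophenyl with 2-phenylcyclopropyl gives an at least 11-fold higher number from compound 1 to compound 3 (1.05 log units; beyond the scatter), so a second, quite different group on this carbonyl carbon also costs activity in this assay. Of the three groups shown, only the 2-chlorophenyl gives a readable number, and the step between compound 2 and compound 3 cannot be read, as both values are limits. The 4-fluorophenyl and 2-phenylcyclopropyl groups therefore cannot be ranked against each other, since the readings stop at one shared limit: the limit of > 30000 nM in this assay, at which 2 of the 3 values shown sit.

Going by these compounds, how far compound 2 and compound 3 actually lie from compound 1 stays open. So does whether a plain phenyl, or a cyclopropyl without its phenyl, on this carbonyl carbon would give a readable number.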